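The compounds below may be only part of what the source reports. "The series", "measured", "known", "first", "only" and "open" are said of these compounds alone.

Compound 1 `CC(=O)Oc1ccccc1C(=O)O[C@H]1CO[C@H]2[C@@H]1OC[C@H]2OC(=O)c1cccc(O)c1`, compound 2 `COc1ccccc1C(=O)O[C@@H]1CO[C@H]2[C@@H]1OC[C@@H]2OC(=O)c1ccccc1OC(C)=O` and compound 3 `COc1ccc(C(=O)O[C@@H]2CO[C@H]3[C@@H]2OC[C@@H]3OC(=O)c2ccccc2OC(C)=O)cc1` share one core and differ only in the ring on one carbonyl carbon. In an ADME assay on a cell-free system (plasma, Homo sapiens) for metabolic stability, with Plasma (Rattus norvegicus) as the target, read by HPLC, at pH 7.4 (a higher number here means that the compound lasts longer, a lower number that the compound disappears faster), compound 1 gives 0.015 h, compound 2 gives 0.0165 h and compound 3 gives 0.0183 h. Compound 3 sits with the other two: a 1.2-fold higher number from compound 1 to compound 3 (0.09 log units; within the scatter) and a 1.1-fold higher number from compound 2 to compound 3 (0.04 log units; within the scatter) are both within the scatter, so nothing separates the three. Compound 4 `CC(=O)Oc1ccccc1C(=O)O[C@H]1CO[C@H]2[C@@H]1OC[C@H]2OC(=O)c1cnoc1C` continues this series with 5-methyl-1,2-oxazol-4-yl in place of 4-methoxyphenyl on a carbonyl carbon. The two steps that swap the ring at that same carbonyl carbon, a 1.2-fold higher number from compound 1 to compound 3 (0.09 log units; within the scatter) and a 1.1-fold higher number from compound 2 to compound 3 (0.04 log units; within the scatter), stayed within the scatter, so no step beyond it is expected in this assay here either. The step expected in this assay is accordingly estimated as a 1.0-fold lower number from compound 3 to compound 4 (0.01 log units; within the scatter). Compound 4 is therefore estimated at 0.018 h, with a range from 0.008 h to 0.04 h.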

Compound 4, half-life: 0.001 h
Compound 4: middle estimate off by 18-fold (1.26 log units), on the high side; measured number below the stated range.
By their numbers in this assay, from the lowest: compound 4; then compounds 1, 2 and 3 (each within the scatter of the next).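

In this assay, the ring on this carbonyl carbon proves able to move the number: with 5-methyl-1,2-oxazol-4-yl there is an 18-fold lower number from compound 3 to compound 4 (1.26 log units; beyond the scatter), a 17-fold lower number from compound 2 to compound 4 (1.22 log units; beyond the scatter) and a 15-fold lower number from compound 1 to compound 4 (1.18 log units; beyond the scatter), whereas the three phenyl rings could not be told apart. At this position, the change from a six-membered aromatic ring of carbon only to a five-membered aromatic ring with 2 hetero atoms goes with faster disappearance.

Nothing available explains this step. On these data alone, it stays open whether a pyridine ring or an unsubstituted 1,2-oxazol-4-yl here would behave like compound 4 or like the phenyl compounds.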